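The compounds below may be only part of what the source reports. "The series", "measured", "known", "first", "only" and "open" are said of these compounds alone.

Measured compounds, with their values in a functional assay on isolated protein for inhibition of Glucose-dependent insulinotropic receptor (Homo sapiens), read by HTRF and cAMP accumulation; on this read-out lower numbers stand for an effect already at smaller amounts and higher numbers for an effect only at larger amounts of compound:

- compound 1, `Cc1nc(S(C)(=O)=O)ccc1Oc1ncnc(OC2CCN(C(=O)OC3(C(F)(F)F)CCC3)CC2)c1F`: 14.3 nM
- compound 2, `Cc1nc(S(C)(=O)=O)ccc1Oc1ncnc(OC2CCN(C(=O)SC(C)C)CC2)c1F`: 6.8 nM
- compound 3, `Cc1nc(S(C)(=O)=O)ccc1Oc1ncnc(OC2CCN(C(=O)C(F)(F)F)CC2)c1F`: 151 nM

Compound 3 stands highest of the three in this assay. The nearest value is that of compound 1, with an 11-fold higher number from compound 1 to compound 3 (1.02 log units; beyond the scatter), and the furthest is that of compound 2, with a 22-fold higher number from compound 2 to compound 3 (1.35 log units; beyond the scatter). Both of these steps replace a larger group on the carbonyl carbon with the trifluoromethyl of compound 3, and both move the number well beyond the scatter.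

Compound 4, `CCC(F)(F)C(=O)N1CCC(Oc2ncnc(Oc3ccc(S(C)(=O)=O)nc3C)c2F)CC1`, is not yet measured. It differs from compound 3 by ethyl in place of fluoro on a saturated chain carbon bound to a carbonyl carbon and two fluorine atoms, so that the trifluoromethyl becomes a 1,1-difluoropropyl. This step again enlarges the group on the carbonyl carbon, as compound 1 and compound 2 do relative to compound 3, though by less and with a different kind of group. A step in this assay that lowers the number beyond the scatter is therefore expected, but smaller than the two measured ones. The expected step is a 3.4-fold lower number from compound 3 to compound 4 (0.53 log units; beyond the scatter). For compound 4 the estimate in this assay is 45 nM, within a range from 15 nM to 130 nM.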

Compound 4, half-maximal effective concentration: 17.4 nM
Compound 4: middle estimate off by 2.6-fold (0.41 log units), on the high side; low and high end bracket the measured number.
By their numbers in this assay, from the lowest: compound 2; then compounds 1 and 4 (each within the scatter of the next); then compound 3.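

In this assay, among these compounds, ethyl in place of fluoro on a saturated chain carbon bound to a carbonyl carbon and two fluorine atoms gives an 8.7-fold lower number from compound 3 to compound 4 (0.94 log units; beyond the scatter), so a change of very few atoms at this place can move the number by much of the distance that the larger groups of the earlier compounds covered. It also shows that a low number here does not need the oxygen or sulfur that links the groups of compound 1 and compound 2 to the carbonyl carbon: the 1,1-difluoropropyl group, with fewer heavy atoms than the ring-bearing group, gives a 1.2-fold higher number from compound 1 to compound 4 (0.09 log units; within the scatter), while isopropylsulfanyl still keeps its edge, with a 2.6-fold higher number from compound 2 to compound 4 (0.41 log units; beyond the scatter).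

Open, from the compounds shown here alone, is whether the two fluorine atoms matter at all, which a plain propyl group would test, and how a longer chain or an amine would behave at this place. No measurement at hand says why the number moves.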